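The source may report more compounds than this note shows. Statements on the series, on what has been measured and on what is new or still open speak of the compounds shown alone.

Of the compounds shown here, two of this study share one core and have been measured. Compound 1 `Cc1ccc(NC(=O)Nc2cc(-c3ccccc3C(=O)O)ccc2Oc2ccccc2C(C)(C)C)cc1` gives, in an assay on HeLa cells for inhibition of Indoleamine 2,3-dioxygenase 1 (Homo sapiens), with stated times of 1 h and 18 h (a lower number here means a stronger inhibitor, a higher number a weaker inhibitor), 70 nM. Compound 2 `CCCCN(CCCC)c1ccc(-c2ccccc2C(=O)O)cc1NC(=O)Nc1ccc(C)cc1` gives in this assay 45 nM. Going by the values given here, the one step that joins them, a 1.6-fold lower number from compound 1 to compound 2 (0.19 log units; within the scatter), is the only measured step so far, and it lies within the scatter. Among the compounds with values here, compound 2 thus stands at the lowest of the two numbers, with compound 1 as its only neighbour and that neighbour within the scatter of it.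

Compound 3 `Cc1ccc(NC(=O)Nc2cc(-c3ccccc3C(=O)O)ccc2N(CC(C)C)C(C)C)cc1` has not been measured in this assay. It differs from compound 2 in one place: isobutyl(isopropyl)amino in place of dibutylamino on an aromatic carbon. Within the data shown here, the group that enters, isobutyl(isopropyl)amino, keeps the same kind of attachment as the dibutylamino that leaves, and the one measured step that touches this position, from compound 1 to compound 2, stayed within the scatter. Among the measured compounds shown here, no measured step shows that the nature of the group at this aromatic carbon moves the number beyond the scatter, so for compound 3 a step of about a 1.1-fold higher number from compound 2 to compound 3 (0.05 log units; within the scatter) is expected, in either direction or none. The estimate for compound 3 in this assay is 50 nM, between 20 nM and 125 nM.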

Compound 3, half-maximal inhibitory concentration: 42 nM
For compound 3 the middle estimate is 1.2-fold (0.08 log units) above the measured one; low and high end bracket the measured number.
By their numbers in this assay, from the lowest: compounds 3, 2 and 1 (each within the scatter of the next).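

In this assay, going by these compounds alone, the step of a 1.1-fold lower number from compound 2 to compound 3 (0.03 log units; within the scatter) replaces one pair of chains on the nitrogen with another and leaves the number within the scatter, which the earlier compounds could not show because they held only one amine at this aromatic carbon. The step of a 1.7-fold lower number from compound 1 to compound 3 (0.22 log units; within the scatter) also stays within the scatter, so the 2-(tert-butyl)phenoxy, dibutylamino and isobutyl(isopropyl)amino groups, each ortho to the ((4-methylphenyl)carbamoyl)amino group and para to the 2-carboxyphenyl group, now give three numbers that cannot be told apart at this position. No evidence at hand bears on why these three numbers lie so close together.

On these data alone, all three groups are large, so it remains open whether a much smaller group at this carbon, such as a plain amino group, a methoxy group or a single hydrogen, or a charged one such as a carboxylic acid, would move the number beyond the scatter. The compounds shown also all keep the carboxylic acid of the 2-carboxyphenyl group and the methyl of the 4-methylphenyl group, so they say nothing about replacing either, for instance the acid with a primary amide or the methyl with a chlorine.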